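The source may report more compounds than this note shows. Statements on the series, on what has been measured and on what is new or still open speak of the compounds shown alone.

Working notes on the series. Two compounds have a number in a physicochemical assay for lipophilicity; on this read-out higher numbers stand for higher lipophilicity and lower numbers for lower lipophilicity. Compound 1, `Cc1ccccc1C1=NO[C@]2(C1)C(=O)O[C@@H]1[C@H]2CC[C@H](C)[C@]2(O)C=CC(=O)[C@@]12C`, gives 1.86 in this assay. Compound 2, `C[C@H]1CC[C@@H]2[C@@H](OC(=O)[C@]23CC(c2ccc(C#N)cc2)N(c2ccccc2)O3)[C@]2(C)C(=O)C=C[C@@]12O`, gives 2.94 in this assay. Of the two numbers compound 2 holds the higher one; the nearest neighbour is compound 1, whose number lies lower by a gap beyond the usual scatter. Going by the values given here, the two compounds differ in more than one place, so no single step between them is counted here.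

Compound 3, `COc1ccc(C2C[C@@]3(ON2c2ccccc2)C(=O)O[C@@H]2[C@H]3CC[C@H](C)[C@]3(O)C=CC(=O)[C@@]23C)cc1Br`, is not yet measured in this assay. Its difference from compound 2 is 3-bromo-4-methoxyphenyl in place of 4-cyanophenyl on a saturated ring carbon. Among the compounds with values here, no measured pair shows a step of this kind, so the expectation rests on the change alone. For compound 3 the step from compound 2 is expected to be upward and beyond the scatter, a number 1.36 log units higher from compound 2 to compound 3 (beyond the scatter). In this assay compound 3 is estimated at 4.3, with a range from 3.6 to 5.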

Compound 3, partition coefficient: 3.98
Compound 3: middle estimate off by 0.32 log units, on the high side; the measured number falls inside the stated range.
By their numbers in this assay, from the lowest: compound 1; then compound 2; then compound 3.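

Going by these compounds alone, this is the first step that can be read at this position, the saturated ring carbon next to the ring nitrogen. In this assay, 3-bromo-4-methoxyphenyl in place of 4-cyanophenyl gives a number 1.04 log units higher from compound 2 to compound 3 (beyond the scatter) and is a large step, so the number responds strongly to a change at this place. Both groups have one six-membered aromatic ring of carbon only, 0 hydrogen-bond donors and 1 hydrogen-bond acceptor, so those counts do not separate them, and nothing available explains the size of the step.

The compounds shown leave open how much of the step goes with the bromine and how much with the methoxy group. They also leave open how a carboxylic acid or an aminomethyl group on the phenyl ring at this place would read.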